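A Pyrimidin-2-yl Exchange on the Shared Core

This account rests on a few compounds, and the source may have more. Where it says the series, first, only, none or still open, it means among the compounds named here.

In an ADME assay on the whole organism (strain 129/SvEvBrd x C57BL/6) for metabolic stability, with Mus musculus as the target (on this read-out lower numbers stand for a shorter-lived compound and higher numbers for a longer-lived compound), two compounds have been measured so far. Compound 1 (`Cc1nc(-c2nc([C@@H](O)[C@H](O)[C@H](O)CO)c[nH]2)cs1`) gives 2.1 h. Compound 2 (`OC[C@@H](O)[C@@H](O)[C@H](O)c1c[nH]c(-c2ncc[nH]2)n1`) gives 3.2 h, and these two numbers lie within the usual scatter of each other, so the pair cannot be ranked.

Compound 3 (`OC[C@@H](O)[C@@H](O)[C@H](O)c1c[nH]c(-c2ncccn2)n1`) has not yet been measured. It differs from compound 2 in one place, with pyrimidin-2-yl in place of 1H-imidazol-2-yl on an aromatic carbon. Within the data shown here, only one measured step bears on this change. That step, a 1.5-fold higher number from compound 1 to compound 2 (0.18 log units; within the scatter), exchanges one aromatic group for another at the same place and stays within the scatter. Among the measured compounds shown here, it is thin evidence, since no measured compound carries pyrimidin-2-yl. Even so, it gives no reason to expect a large shift in either direction in this assay. The expected change, a 1.2-fold lower number from compound 2 to compound 3 (0.07 log units; within the scatter), is therefore estimated to stay within the scatter. Compound 3 is expected to give about 2.7 h, with an estimated range of 1.3 h to 5.5 h.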

Compound 3, half-life: 2.4 h
Estimate against measurement, compound 3: 1.1-fold (0.05 log units) above, within the range that was stated.
By their numbers in this assay, from the lowest: compounds 1, 3 and 2 (each within the scatter of the next).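

In this assay, a six-membered aromatic ring now stands at this place, on an aromatic carbon between two ring nitrogen atoms, and the exchange for 1H-imidazol-2-yl gives a 1.3-fold lower number from compound 2 to compound 3 (0.12 log units; within the scatter) while the exchange for 2-methyl-1,3-thiazol-4-yl gives a 1.1-fold higher number from compound 1 to compound 3 (0.06 log units; within the scatter) in the same assay. The change also takes the group at this place from 1 hydrogen-bond donor to 0 hydrogen-bond donors, and neither this nor the different ring size comes with a step beyond the scatter, so the three aromatic groups shown cannot be told apart on half-life. Nothing further has been measured that would explain this result.

As far as these compounds go, whether a group of another kind at this place, such as an amine, a carboxylic acid or a longer alkyl chain, would carry the half-life beyond the scatter remains open. All three compounds also keep the same group of 8 heavy atoms, so the compounds shown say nothing about how that part of the shared core bears on the read-out.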